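The source may hold more compounds than are shown below. What is called first, only, known or untested is meant among the compounds shown, and "the series" means these compounds.

Measured so far in a functional assay on MCF7 cells (Homo sapiens) for antiproliferative activity, read by MTT assay, with a stated time of 72 h; a lower number here means a stronger inhibitor, a higher number a weaker inhibitor:

compound 1 `COc1cc(/C=C/c2ccc(C3=C(c4ccc(O)cc4)C4CC(S(=O)(=O)Oc5ccc(Br)cc5)C3O4)cc2)cc(OC)c1`: > 100000 nM
compound 2 `O=S(=O)(Oc1ccc(Br)cc1)C1CC2OC1C(c1ccc(/C=C/c3cc(O)cc(O)c3)cc1)=C2c1ccc(O)cc1`: 16900 nM
compound 3 `COc1cc(/C=C/c2cccc(OS(=O)(=O)C3CC4OC3C(c3ccc(O)cc3)=C4c3ccc(O)cc3)c2)cc(OC)c1`: 11500 nM

The value of compound 1 is a limit of this assay, not a number. Compound 2 gives 16900 nM in this assay, and compound 3 gives 11500 nM; these two values lie within the usual scatter of each other. The step of an at least 5.9-fold lower number from compound 1 to compound 2 (0.77 log units; beyond the scatter) comes with the change (3,5-dihydroxyphenyl in place of 3,5-dimethoxyphenyl on a double-bonded chain carbon bound to a double-bonded chain carbon), and it is known only as a lower bound because of the limit of > 100000 nM in this assay, at which 1 of the 3 values shown sits. How the core of compound 3 differs from that of compound 1 is not broken down here.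

Compound 4 `O=S(=O)(Oc1cccc(/C=C/c2cc(O)cc(O)c2)c1)C1CC2OC1C(c1ccc(O)cc1)=C2c1ccc(O)cc1` is not yet measured. It arises from compound 3 by 3,5-dihydroxyphenyl in place of 3,5-dimethoxyphenyl on a double-bonded chain carbon bound to a double-bonded chain carbon, the same change that leads from compound 1 to compound 2. Since the earlier step is at least modest, a drop of similar size is expected here too, though from a starting value that is already a number rather than a limit. The expected step is a 2.9-fold lower number from compound 3 to compound 4 (0.46 log units; beyond the scatter), resting on the step of an at least 5.9-fold lower number from compound 1 to compound 2 (0.77 log units; beyond the scatter). For compound 4 the estimate in this assay is 4000 nM, between 1500 nM and 12000 nM.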

Compound 4, half-maximal inhibitory concentration: 17800 nM
Estimate against measurement, compound 4: 4.5-fold (0.65 log units) below; measured number outside the range, above it.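

In this assay, putting 3,5-dihydroxyphenyl in place of 3,5-dimethoxyphenyl on the other core gives a 1.5-fold higher number from compound 3 to compound 4 (0.19 log units; within the scatter), and the two cores clearly do not answer this change alike: the same change on two cores in this assay, an at least 5.9-fold lower number (0.77 log units; beyond the scatter) from compound 1 to compound 2 and a 1.5-fold higher number (0.19 log units; within the scatter) from compound 3 to compound 4, at least 9.1-fold (0.96 log units) apart, beyond the scatter of two such steps. This shows that the change does not carry over from one core to the other in this series, so the size of the step on one core is a poor guide to the step on the other, although two pairs cannot show which feature of the cores sets them apart. Going by these compounds, compound 1 stands at a limit, not a number, so the true size of the earlier step remains unknown: the limit of > 100000 nM in this assay, at which 1 of the 4 values shown sits.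

The compounds shown leave open how other groups in the same place would behave on these two cores, such as a phenyl ring carrying two amines or a carboxylic acid. Also open, on these data alone, is whether a ring with one hydroxyl and one methoxy would follow either core's pattern.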